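Swapping propargylamino on a carbonyl carbon of compound 3

This account rests on a few compounds, and the source may have more. Where it says the series, first, only, none or still open, it means among the compounds named here.

Of the compounds shown here, three have been measured in a functional assay on PC-3 cells (Homo sapiens), read by MTT assay, with a stated time of 48 h; a higher number here means a weaker inhibitor, a lower number a stronger inhibitor. Compound 1 (`CCN(CC)CCCNC(=O)c1ccc(C(CC)(CC)c2ccc(OCC(=O)C(C)(C)C)c(C)c2)n1CC`) gives 1800 nM, and compound 2 (`CCn1c(C(=O)NCCN)ccc1C(CC)(CC)c1ccc(OCC(=O)C(C)(C)C)c(C)c1`) gives 480 nM. Compound 3 (`C#CCNC(=O)c1ccc(C(CC)(CC)c2ccc(OCC(O)C(C)(C)C)c(C)c2)n1CC`) gives 16200 nM, the highest of the three numbers and well clear of both others.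

The next compound, compound 4 (`C#CC(C)OC(=O)c1ccc(C(CC)(CC)c2ccc(OCC(O)C(C)(C)C)c(C)c2)n1CC`), departs from compound 3 at one place: (1-methylprop-2-yn-1-yl)oxy in place of propargylamino on a carbonyl carbon. The counted difference is (1-methylprop-2-yn-1-yl)oxy in place of propargylamino on a carbonyl carbon.

Among the compounds with values here, only one step between measured compounds is available, and it bears on this change only weakly. That step, a 3.8-fold lower number from compound 1 to compound 2 (0.57 log units; beyond the scatter), is modest, but it concerns a group on a saturated chain carbon and leaves the group on the carbonyl carbon in place of an exchange like this one. Within the data shown here, no measured pair shows what this exchange does, so neither direction can be favoured. The expectation therefore stays anchored on compound 3 at 16200 nM, with no step beyond the scatter foreseen and a wide margin for the untested change.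

The expected step is a 1.2-fold lower number from compound 3 to compound 4 (0.10 log units; within the scatter). For compound 4 the estimated value is 13000 nM. The expected range for compound 4 runs from 4500 nM to 38000 nM.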

Compound 4, half-maximal inhibitory concentration: 38200 nM
The estimate for compound 4 lay 2.9-fold (0.47 log units) below the measured number, and the stated range ends below it.
By their numbers in this assay, from the lowest: compound 2; then compound 1; then compound 3; then compound 4.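

In this assay, exchanging propargylamino for (1-methylprop-2-yn-1-yl)oxy on the carbonyl carbon gave a 2.4-fold higher number from compound 3 to compound 4 (0.37 log units; beyond the scatter), so this position responds to the exchange, and the response is a modest loss of strength rather than a neutral swap. The exchange keeps the triple bond and adds no ring or net charge, but by count it removes the hydrogen-bond donor, adds a hydrogen-bond acceptor, replaces nitrogen with oxygen and brings one more heavy atom, so these differences travel together in this single step. No supporting information is available to explain why the number rose.

The step cannot show whether the change in the linking atom or the added methyl branch matters more, and propargyloxy without that branch or an N-methylated propargylamino group would help to separate the two. Also open, on these data alone, are the effects of a carboxylic acid or a longer amine chain on the same carbonyl carbon, and whether the step would hold in compounds carrying a ketone in place of the alcohol found in compound 3 and compound 4.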